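The compounds below may be only part of what the source reports. "The series", "measured", "known", "first", "only" and "open" are said of these compounds alone.

Three close relatives share one core and differ only in the group on an oxygen on an aromatic ring. In an ADME assay on the whole organism (plasma, Rattus norvegicus) for protein binding, using cassette dosing, at a dose of 1 mg/kg (on this read-out higher numbers stand for a larger free fraction and lower numbers for a smaller free fraction), compound 1 `C[C@@H](Cn1c(=O)[nH]/c(=N\c2ccc(Oc3ccc(F)cn3)cc2)n(Cc2ccc(Cl)cc2)c1=O)C(=O)O` gives 0.011, compound 2 `C[C@@H](Cn1c(=O)[nH]/c(=N\c2ccc(Oc3cnccn3)cc2)n(Cc2ccc(Cl)cc2)c1=O)C(=O)O` gives 0.018 and compound 3 `C[C@@H](Cn1c(=O)[nH]/c(=N\c2ccc(Oc3ccccn3)cc2)n(Cc2ccc(Cl)cc2)c1=O)C(=O)O` gives 0.01. These numbers all lie within the usual scatter of one another, so compound 3 cannot be ranked against the other two.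

Compound 4 `C[C@@H](Cn1c(=O)[nH]/c(=N\c2ccc(OC3CCC3)cc2)n(Cc2ccc(Cl)cc2)c1=O)C(=O)O` keeps the core and carries one change: cyclobutyl in place of pyridin-2-yl on an oxygen on an aromatic ring. In words, this is cyclobutyl in place of pyridin-2-yl on an oxygen on an aromatic ring.

Among the measured compounds shown here, three measured steps touch the same group. Putting hydrogen in place of fluoro gives a 1.1-fold lower number from compound 1 to compound 3 (0.04 log units; within the scatter), pyridin-2-yl in place of pyrazin-2-yl gives a 1.8-fold lower number from compound 2 to compound 3 (0.26 log units; within the scatter), and pyrazin-2-yl in place of 5-fluoropyridin-2-yl gives a 1.6-fold higher number from compound 1 to compound 2 (0.21 log units; within the scatter). All three are small, but each leaves an aromatic ring on the oxygen, so none tests a non-aromatic ring there and the evidence is only indirect.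

With that caution, no change beyond the scatter is expected in this assay. The estimated step is a 1.1-fold lower number from compound 3 to compound 4 (0.05 log units; within the scatter). The expected value for compound 4 is 0.009, with a range from 0.004 to 0.018.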

Compound 4, unbound fraction: 0.015
For compound 4 the middle estimate is 1.7-fold (0.22 log units) below the measured one, and the stated range covers the measured number.
By their numbers in this assay, from the lowest: compounds 3, 1, 4 and 2 (each within the scatter of the next).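

Among the compounds shown here, compound 4 is the first of these relatives to carry a non-aromatic ring on the oxygen, and in this assay the replacement of each aromatic group by cyclobutyl stays within the scatter (a 1.5-fold higher number from compound 3 to compound 4 (0.18 log units; within the scatter); a 1.4-fold higher number from compound 1 to compound 4 (0.13 log units; within the scatter); a 1.2-fold lower number from compound 2 to compound 4 (0.08 log units; within the scatter)). On these four compounds, then, the group on the oxygen can lose both its aromatic character and its ring nitrogen, going from pyridin-2-yl to a ring of carbon only, without a change that this read-out can distinguish from the scatter. No measurement at hand offers an explanation for this result.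

The compounds shown leave open whether a group on the oxygen that is not a ring at all, such as a straight butyl chain, or a cyclobutyl ring carrying an amine or a carboxylic acid, would also stay within the scatter. On these data alone, whether the same replacement would read alike on a different core also remains open.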